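Swapping an ethynyl for an aryl triazole

The compounds below may be only part of what the source reports. "The series", "measured", "known", "first", "only" and "open" are said of these compounds alone.

Compound 1 `COc1ccccc1-n1cc(COC(=O)/C(C)=C/CC/C(C)=C/CC/C(C)=C/CC[C@@H]2[C@@]3(C)CCC(=O)C(C)(C)[C@H]3CC[C@@]2(C)O)nn1` gives > 150000 nM (a limit, not a number)
Compound 2 `C/C(=C\CC/C(C)=C/CC[C@@H]1[C@@]2(C)CCC(=O)C(C)(C)[C@H]2CC[C@@]1(C)O)CC/C=C(\C)C(=O)OCc1cn(C[C@@H]2O[C@H](n3ccc(=O)[nH]c3=O)C[C@H]2O)nn1` gives 26300 nM (a measured number)
Compound 3 `C#CCOC(=O)/C(C)=C/CC/C(C)=C/CC/C(C)=C/CC[C@@H]1[C@@]2(C)CCC(=O)C(C)(C)[C@H]2CC[C@@]1(C)O` gives 114000 nM (a measured number)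

All three values come from a functional assay on MDA-MB-231 cells (Homo sapiens) for antiproliferative activity, read by MTT assay, with a stated time of 48 h; a lower number here means a stronger inhibitor, a higher number a weaker inhibitor (the only test used here). Compound 3 holds the higher of the two real numbers, and compound 2 sits lower by a gap beyond the scatter. Both are weak in absolute terms.

Going by the values given here, compound 4 `C/C(=C\CC/C(C)=C/CC[C@@H]1[C@@]2(C)CCC(=O)C(C)(C)[C@H]2CC[C@@]1(C)O)CC/C=C(\C)C(=O)OCc1cn(-c2cccc(Cl)c2)nn1` has 1-(3-chlorophenyl)-1H-1,2,3-triazol-4-yl in place of ethynyl on a saturated chain carbon bound to an oxygen next to a carbonyl group (its single change from compound 3).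

The closest model is compound 1, which also carries an aromatic ring on a triazole, and its > 150000 nM value is a limit. Compound 2 has a triazole too, but its substituent is quite different.

In this assay the expected result is no step beyond the scatter, an estimated change of a 1.1-fold lower number from compound 3 to compound 4 (0.06 log units; within the scatter) (a rough expectation). For compound 4 the estimate is 100000 nM (expected range 35000 nM to 220000 nM).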

Compound 4, half-maximal inhibitory concentration: 103000 nM
Compound 4: the middle estimate sits 1.0-fold (0.01 log units) below what was measured; measured number inside the range.
By their numbers in this assay, from the lowest: compound 2; then compounds 4 and 3 (each within the scatter of the next). At a limit, above all of these: compound 1.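

In this assay, the step for 1-(3-chlorophenyl)-1H-1,2,3-triazol-4-yl in place of ethynyl on a saturated chain carbon bound to an oxygen next to a carbonyl group is a 1.1-fold lower number from compound 3 to compound 4 (0.04 log units; within the scatter), so this position accepts a group with two aromatic rings with no change that can be told from the scatter. The step for 3-chlorophenyl in place of 2-methoxyphenyl on an aromatic nitrogen is an at least 1.4-fold lower number from compound 1 to compound 4 (0.16 log units; that floor lies within the scatter); it rests on a limit, so it gives only a floor and not a true size. Compound 1 is the one compound at that limit: the limit of > 150000 nM in this assay, at which 1 of the 4 values shown sits.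

On these data alone, what a pyridine ring would do in place of 3-chlorophenyl on the aromatic nitrogen remains open. The same holds for a benzoic acid or an aniline there.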